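Aryl variation on the ring nitrogen: antiproliferative notes

The source may hold more compounds than are shown below. What is called first, only, known or untested is meant among the compounds shown, and "the series" means these compounds.

Measured in an ADME assay on HUVEC cells (Homo sapiens) for antiproliferative activity, read by MTT assay, with a stated time of 48 h; a lower number here means a stronger inhibitor, a higher number a weaker inhibitor:
Compound 1, `Cc1cccc(-n2nncc2CN2C(=O)C3(C(C#N)=C(N)Oc4c3c3nc5ccccc5nc3c3ccccc43)c3ccccc32)c1`: limit of > 50000 nM
Compound 2, `N#CC1=C(N)Oc2c(c3nc4ccccc4nc3c3ccccc23)C12C(=O)N(Cc1cnnn1-c1ccccc1Cl)c1ccccc12`: limit of > 50000 nM
Compound 3, `CCOc1ccc(-n2nncc2CN2C(=O)C3(C(C#N)=C(N)Oc4c3c3nc5ccccc5nc3c3ccccc43)c3ccccc32)cc1`: limit of > 50000 nM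

Each of these values is a limit of this assay and not a number. Compound 3 therefore stands at the limit, as do the other two, and none of the three can be ordered against another. The steps a step that the two limits leave unreadable from compound 1 to compound 2, a step that the two limits leave unreadable from compound 1 to compound 3 and a step that the two limits leave unreadable from compound 2 to compound 3 cannot be sized, since both ends of each sit at the limit of > 50000 nM in this assay, at which 3 of the 3 values shown sit. Compound 4, `Cc1ccc(-n2nncc2CN2C(=O)C3(C(C#N)=C(N)Oc4c3c3nc5ccccc5nc3c3ccccc43)c3ccccc32)cc1C`, differs from compound 3 by 3,4-dimethylphenyl in place of 4-ethoxyphenyl on an aromatic nitrogen. This aryl exchange is of the same kind as the three unreadable steps, each of which kept a limit. The expected step for compound 4 is a number no higher from compound 3 to compound 4 (the limit leaves the size open), most likely again unreadable. Compound 4 is expected at 50000 nM, range 20000 nM to 100000 nM, probably reported once more as a limit.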

Compound 4, half-maximal inhibitory concentration: > 50000 nM
Compound 4: only a limit was reported (the forecaster's own chance of this, stated with the estimate: 85%); the middle value sits exactly at the limit.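

Compound 4 adds no readable step against compound 1, compound 2 or compound 3, since all four values are limits and not numbers: the limit of > 50000 nM in this assay, at which 4 of the 4 values shown sit.

On these data alone, whether any of these aryl groups differs from another in activity remains open.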